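The source may report more compounds than this note shows. Statements on the series, on what has been measured and on what is new or still open speak of the compounds shown alone.

Measured so far:

Compound 1, `C=CC(=O)Nc1ccc(-n2nc3c(=O)[nH]nc(N)c3c2-c2oc3ccc(Cl)cc3c2C)cc1`: in a physicochemical assay for solubility, read by nephelometry, in phosphate buffer, measured as kinetic solubility, at pH 7.4 (a higher number here means a more soluble compound, a lower number a less soluble compound), compound 1 gives 20000 nM.
Compound 2, `C=CC(=O)Nc1ccc(-n2nc3c(=O)[nH]nc(N)c3c2-c2oc3ccc(C)cc3c2C)cc1`: in this assay compound 2 gives 20000 nM.
Compound 3, `CCOC(=O)c1oc2ccc(C)cc2c1C`: in this assay compound 3 gives 200000 nM.

Compound 1 and compound 2 share one core and differ only by chloro in place of methyl on an aromatic carbon. For the measured compounds named here, that step, no change at the digits printed from compound 2 to compound 1 (within the scatter), is the one example of this exchange with a measured outcome. Compound 3 stands on a different core; the difference between the core of compound 3 and the core of compound 2 is not broken down here, and compound 3 simply gives the highest of the three numbers.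

Compound 4, `CCOC(=O)c1oc2ccc(Cl)cc2c1C`, is not yet measured. It differs from compound 3 by chloro in place of methyl on an aromatic carbon. The place is described in the same words as for the step from compound 2 to compound 1, so this is the same change, now applied to the core of compound 3.

For compound 4 a step of a 1.3-fold lower number from compound 3 to compound 4 (0.10 log units; within the scatter) is expected in this assay, because no change at the digits printed from compound 2 to compound 1 (within the scatter) showed no movement for the same exchange. That rests on a single measured pair and on a different core, so the expectation is loose. Compound 4 is estimated at 160000 nM, expected between 70000 nM and 350000 nM.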

Compound 4, solubility: 200000 nM
Compound 4: middle estimate off by 1.3-fold (0.10 log units), on the low side; the measured number falls inside the stated range.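

In this assay chloro in place of methyl on an aromatic carbon gives no change at the digits printed from compound 3 to compound 4 (within the scatter) and on the other core gives no change at the digits printed from compound 2 to compound 1 (within the scatter) so the exchange reads alike on the two cores shown. For the compounds shown here, these are only two matched pairs, each with the exchange at a single place, so they do not show that the result carries to a third core or to another carbon of the ring, and a small shift inside the usual scatter cannot be told apart from none. No measurement shown here explains why the two pairs read alike.

Only methyl and chloro appear at this aromatic carbon among the compounds shown, so it remains open how an amine, a carboxylic acid or a longer chain at the same place would read. From the compounds shown here alone, it also remains open whether the ethyl ester of compound 3 and compound 4 could give way to a carboxylic acid or an amide without changing this reading.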